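Compound 3 to compound 4: methyl in place of fluoro

A few compounds are considered here, and "the series" means these few. Any claim that something is new, unique, unknown or untested is made for them only; others in the source may bear on it.

Values in a functional assay on HepG2 cells (Homo sapiens) for antiproliferative activity, read by spectrophotometry, with a stated time of 2 days; on this read-out lower numbers stand for stronger inhibition of growth and higher numbers for weaker inhibition of growth:
Compound 1 `COc1ccc(C(F)(F)F)cc1Nc1ncc(C(F)(F)F)c(N2Cc3cccc(N(C)S(C)(=O)=O)c3C2)n1`: > 30000 nM, a limit
Compound 2 `COc1cc(N2CCN(C(C)=O)CC2)ccc1Nc1ncc(C(F)(F)F)c(N2Cc3cccc(N(C)S(C)(=O)=O)c3C2)n1`: 3800 nM
Compound 3 `Cc1cc(F)ccc1Nc1ncc(C(F)(F)F)c(N2Cc3cccc(N(C)S(C)(=O)=O)c3C2)n1`: 16800 nM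

Among the two values that are actual numbers, compound 3 at 16800 nM stands highest. Compound 2 lies lower at 3800 nM, a gap beyond the usual scatter. Compound 4 `Cc1ccc(Nc2ncc(C(F)(F)F)c(N3Cc4cccc(N(C)S(C)(=O)=O)c4C3)n2)c(C)c1` carries methyl in place of fluoro on an aromatic carbon, meta to a methyl group and para to a large group, turning 4-fluoro-2-methylphenyl into 2,4-dimethylphenyl: methyl in place of fluoro on an aromatic carbon. For the measured compounds named here, the only measured step that bears on this change is an at least 1.7-fold lower number from compound 1 to compound 3 (0.25 log units; that floor lies within the scatter). That step starts from a limit and exchanges the whole substituent on the nitrogen, so it gives no size for a single methyl-for-fluoro exchange. With compound 3 as the anchor, no step beyond the scatter is expected in this assay. The estimated change is a 1.0-fold higher number from compound 3 to compound 4 (0.01 log units; within the scatter), which is expected to stay within the scatter. Compound 4 is estimated at 17000 nM, with an expected range of 8000 nM to 30000 nM.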

Compound 4, concentration for 50% growth inhibition: 19100 nM
Compound 4: the middle estimate sits 1.1-fold (0.05 log units) below what was measured, within the range that was stated.
By their numbers in this assay, from the lowest: compound 2; then compounds 3 and 4 (each within the scatter of the next). At a limit, above all of these: compound 1.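

In this assay, for the compounds shown here, the first single exchange at this position, methyl for fluoro on an aromatic carbon para to a large group, gives no change that can be told from the scatter: a 1.1-fold higher number from compound 3 to compound 4 (0.06 log units; within the scatter). The wider exchange of the whole substituent on the nitrogen, to 2,4-dimethylphenyl, can be read only as a floor: an at least 1.5-fold lower number from compound 1 to compound 4 (0.19 log units; that floor lies within the scatter). Compound 1 stands at a limit and not at a number, so the true size of that step cannot be read: the limit of > 30000 nM in this assay, at which 1 of the 4 values shown sits.

With only fluoro and methyl compared here, no trend can be drawn for this position. From the compounds shown here alone, whether an amine, a carboxylic acid or a longer chain in the same place would move the number beyond the scatter remains open.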